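A few compounds are considered here, and "the series" means these few. Any claim that something is new, unique, unknown or untested is made for them only; others in the source may bear on it.

In an assay on microsomes from liver for inhibition of acyl-CoA desaturase 1 (Rattus norvegicus) (a lower number here means a stronger inhibitor, a higher number a weaker inhibitor), compound 1 `CC(C)c1nnc(-c2ccc(N3CCC(Oc4ccccc4C(F)(F)F)CC3)nn2)s1` gives 8.8 nM, the lowest of the two numbers at hand. For the measured compounds named here, the only other measured compound, compound 2 `COc1ccccc1OC1CCN(c2ccc(-n3ccnc3)nn2)CC1`, gives 543 nM in this assay; since the two compounds differ in several places at once, that gap says nothing about any single change. Compound 3 `CC(C)Cc1nnc(-c2ccc(N3CCC(Oc4ccccc4C(F)(F)F)CC3)nn2)o1` has not yet been measured. It differs from compound 1 in one place: 5-isobutyl-1,3,4-oxadiazol-2-yl in place of 5-isopropyl-1,3,4-thiadiazol-2-yl on an aromatic carbon. The five-membered ring on the shared core thus has an oxygen where compound 1 has a sulfur, and its branched chain is longer. Going by the values given here, no measured pair shows this change, so the expectation rests on the change itself, which is confined to one ring and its chain at the edge of the molecule. Relative to compound 1, compound 3 is expected to show a step of a 2.0-fold higher number from compound 1 to compound 3 (0.31 log units; beyond the scatter), a mild weakening that may well stay within the scatter. Compound 3 is therefore estimated at 18 nM, within a range from 6 nM to 60 nM.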

Compound 3, half-maximal inhibitory concentration: 15 nM
Compound 3: middle estimate off by 1.2-fold (0.08 log units), on the high side, within the range that was stated.
By their numbers in this assay, from the lowest: compounds 1 and 3 (each within the scatter of the next); then compound 2.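

In this assay, the step is a 1.7-fold higher number from compound 1 to compound 3 (0.23 log units; within the scatter), so the two compounds cannot be told apart here, even though the group on this aromatic carbon was exchanged for a different one. For the compounds shown here, this is the first sign that the position accepts more than one group: 5-isopropyl-1,3,4-thiadiazol-2-yl, with 8 heavy atoms, and 5-isobutyl-1,3,4-oxadiazol-2-yl, with 9, give results within the usual scatter, and both have one five-membered aromatic ring with 3 hetero atoms and the same counts of hydrogen-bond donors and acceptors. No measurement at hand explains this outcome.

Going by these compounds alone, two things changed together, the ring's sulfur to oxygen and the isopropyl chain to isobutyl, so the single step cannot show whether each change alone matters little or whether the two happen to balance, and a compound with 5-isopropyl-1,3,4-oxadiazol-2-yl or 5-isobutyl-1,3,4-thiadiazol-2-yl would separate them. As far as these compounds go, how far this tolerance extends also remains open, for instance whether the five-membered ring could carry a longer chain, an amine or a carboxylic acid in place of the isobutyl group.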